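This account rests on a few compounds, and the source may have more. Where it says the series, first, only, none or still open, it means among the compounds named here.

Measured so far in a functional assay on HT-29 cells (Homo sapiens) for antiproliferative activity, read by MTT assay, with a stated time of 24 h; a higher number here means a weaker inhibitor, a lower number a stronger inhibitor:
Compound 1, `COc1cccc(/C=C/C(=O)c2ccc(OC)c3c2OC(C)(C)C=C3)c1`, gives > 10000 nM, which is a limit of the assay.
Compound 2, `COc1ccc(C(=O)/C=C/c2cc(OC)c(OC)c(OC)c2)c2c1C=CC(C)(C)O2`, gives > 10000 nM, which is a limit of the assay.
Compound 3, `COc1ccc(C(=O)/C=C/c2cccc(O)c2)c2c1C=CC(C)(C)O2`, gives > 10000 nM, which is a limit of the assay.

Compound 3 arises from compound 1 by one change: hydrogen in place of methyl on an oxygen on an aromatic ring. The step that the two limits leave unreadable from compound 1 to compound 3 cannot be sized, because of the limit of > 10000 nM in this assay, at which 3 of the 3 values shown sit. How the core of compound 2 differs from the core of compound 1 is not broken down here.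

Compound 4, `COc1cc(/C=C/C(=O)c2ccc(OC)c3c2OC(C)(C)C=C3)cc(OC)c1O`, is not yet measured. It arises from compound 2 by hydrogen in place of methyl on an oxygen on an aromatic ring, the same change as from compound 1 to compound 3, at the same kind of place. Since that earlier step is unreadable and compound 2 sits at the limit, the step that the limit leaves unreadable from compound 2 to compound 4 is expected to be small. Compound 4 is therefore expected to give about 15000 nM, between 4000 nM and 60000 nM, most likely again reported as a limit.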

Compound 4, half-maximal inhibitory concentration: > 10000 nM
Compound 4: only a limit was reported; the forecaster's own chance of this, stated with the estimate: 75%; the middle value lies beyond the limit too.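

No size can be given for the change from methoxy to hydroxy between compound 2 and compound 4, because both values are limits: the limit of > 10000 nM in this assay, at which 4 of the 4 values shown sit.

The compounds shown leave open which change to these structures, if any, would give an actual number rather than a limit in this assay.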